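Homologating the Amide Cap on a Chlorophenylpiperidine Series

The source may report more compounds than this note shows. Statements on the series, on what has been measured and on what is new or still open speak of the compounds shown alone.

Three compounds have been measured in an assay on THP-1 cells for displacement of a labelled ligand from C-C chemokine receptor type 1 (Homo sapiens); a lower number here means a stronger inhibitor, a higher number a weaker inhibitor:

Compound 1, `CC[C@@H](NC(=O)c1ccccc1)C(=O)N1CCC(c2ccc(Cl)cc2)CC1`, gives 121 nM.
Compound 2, `Cc1ccc(C(=O)N[C@@H](C(=O)N2CCC(c3ccc(Cl)cc3)CC2)C(C)C)cc1`, gives 25 nM.
Compound 3, `CC[C@@H](C)[C@@H](NC(=O)c1ccccc1)C(=O)N1CCC(c2ccc(Cl)cc2)CC1`, gives 45 nM.

Within the data shown here, compound 3 sits second highest of the three numbers: it lies within the scatter of compound 2, and the one step that bears on it, a 2.7-fold lower number from compound 1 to compound 3 (0.43 log units; beyond the scatter), is beyond the scatter and modest in size. Among the measured compounds shown here, compound 2 differs from compound 3 in two places at once, so its value shows only that the two compounds are close.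

Compound 4, `CC[C@@H](C)[C@@H](NC(=O)CCc1ccccc1)C(=O)N1CCC(c2ccc(Cl)cc2)CC1`, is the next one to be measured. It differs from compound 3 in a single place: phenethyl in place of phenyl on a carbonyl carbon. For the measured compounds named here, none of the measured steps touches this part of the molecule; the only measured step concerns the side chain, not the cap on the amide nitrogen. Nothing in the data therefore points in either direction, and the expectation is a step of no clear sign, with wide uncertainty: a 1.3-fold higher number from compound 3 to compound 4 (0.12 log units; within the scatter). Compound 4 is accordingly estimated at 60 nM, with a range from 20 nM to 200 nM.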

Compound 4, half-maximal inhibitory concentration: 66 nM
Beside the measured number, compound 4's estimate is 1.1-fold (0.04 log units) below it; low and high end bracket the measured number.
By their numbers in this assay, from the lowest: compounds 2, 3, 4 and 1 (each within the scatter of the next, the first and the last beyond it).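

In this assay, phenethyl in place of phenyl on the carbonyl carbon gives a 1.5-fold higher number from compound 3 to compound 4 (0.17 log units; within the scatter), so this change, the first measured at the cap rather than the side chain, does not move the number beyond the scatter. The series can therefore carry either group at this position, each with its six-membered aromatic ring of carbon only and neither adding a hydrogen-bond donor or acceptor, with no measurable separation between them. No supporting measurement is available to explain this outcome.

The compounds shown leave open whether a still longer chain, such as phenylbutyl, would also stay within the scatter, or whether an amine or a carboxylic acid on the phenethyl ring would shift the number. They also leave open whether a cyclohexyl group could replace the aromatic ring at this position.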